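A Methyl Added to a Weakly Antiproliferative Scaffold

The source may hold more compounds than are shown below. What is called first, only, known or untested is meant among the compounds shown, and "the series" means these compounds.

Going by the values given here, compound 1, `O=c1c(Cc2coc3cccc(OCC4CCCCC4)c3c2=O)coc2ccccc12`, is the only compound of this set that yields a number in a functional assay on NCI-H23 cells (Homo sapiens) for antiproliferative activity, read by XTT assay; on this read-out lower numbers stand for stronger inhibition and higher numbers for weaker inhibition: compound 1 gives 4130 nM. Compound 2, `O=c1c(/C=C/c2coc3ccccc3c2=O)coc2ccccc12`, gives only a limit in this assay, > 10000 nM. Compound 3, `CC(C)CCOc1cccc2occ(Cc3coc4ccccc4c3=O)c(=O)c12`, likewise gives only a limit, > 10000 nM. Among the compounds with values here, the one step that can be compared, an at least 2.4-fold higher number from compound 1 to compound 3 (0.38 log units; beyond the scatter), runs into (the limit of > 10000 nM in this assay, at which 2 of the 3 values shown sit), so its true size is not known. Compound 4, `Cc1ccc2c(=O)c(Cc3coc4cccc(OCC5CCCCC5)c4c3=O)coc2c1`, differs from compound 1 by methyl in place of hydrogen on an aromatic carbon. Within the data shown here, no measured step alters this part of the structure; the only step known concerns the saturated chain carbon bound to an oxygen on an aromatic ring and so does not bear on the present change. With nothing pointing in either direction, the expectation for compound 4 is a number close to that of compound 1, and a 1.0-fold lower number from compound 1 to compound 4 (0.01 log units; within the scatter) is expected to stay within the scatter. Compound 4 is therefore estimated at 4000 nM, with a range from 1500 nM to 10000 nM.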

Compound 4, half-maximal inhibitory concentration: 3220 nM
For compound 4 the middle estimate is 1.2-fold (0.09 log units) above the measured one, within the range that was stated.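

In this assay, methyl in place of hydrogen on an aromatic carbon gives a 1.3-fold lower number from compound 1 to compound 4 (0.11 log units; within the scatter), so compound 1 and compound 4 cannot be told apart. Going by these compounds alone, this is the first measured change to this ring of carbon only, and it shows that one added methyl at this carbon leaves the number within the scatter of repeated measurements. Both ends of this step are true numbers, whereas compound 2 and compound 3 stop at a limit of the assay: the limit of > 10000 nM in this assay, at which 2 of the 4 values shown sit.

Going by these compounds, whether an amine, a carboxylic acid or a longer chain at the same carbon would also leave the number unchanged remains open. So does whether methyl would behave the same way on the other carbons of this ring.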